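Cytotoxicity limits across an amide-type nitrogen swap

A few compounds are considered here, and "the series" means these few. Any claim that something is new, unique, unknown or untested is made for them only; others in the source may bear on it.

Measured compounds:
compound 1 `O=C(Cn1c(-c2ccccc2)cc(-c2ccccc2)c1-c1ccco1)Nc1nc2ccccc2s1`, < 50000 nM, a limit of the assay
compound 2 `O=C(Cn1c(-c2ccccc2)cc(-c2ccccc2)c1-c1ccco1)Nc1ccccn1`, < 50000 nM, a limit of the assay
compound 3 `O=C(Cn1c(-c2ccccc2)cc(-c2ccccc2)c1-c1ccc(Br)cc1)Nc1nc2ccccc2s1`, < 50000 nM, a limit of the assay

In an ADME assay on HEK-293T cells (Homo sapiens) for cytotoxicity, read by MTT assay, with a stated time of 72 h (a lower number here means a stronger inhibitor, a higher number a weaker inhibitor), compound 1 gives < 50000 nM, which is a limit and not a number. In this assay compound 2 gives < 50000 nM, again a limit. In this assay compound 3 gives < 50000 nM, also a limit. The change from compound 1 to compound 2 is pyridin-2-yl in place of 1,3-benzothiazol-2-yl on an amide-type nitrogen; its step is a step that the two limits leave unreadable from compound 1 to compound 2. The cores of compound 1 and compound 3 differ by 4-bromophenyl in place of furan-2-yl on an aromatic carbon, and that step is a step that the two limits leave unreadable from compound 1 to compound 3. Going by the values given here, the only evidence on these steps is the limit of < 50000 nM in this assay, at which 3 of the 3 values shown sit, so no size can be read for either.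

Compound 4 `O=C(Cn1c(-c2ccccc2)cc(-c2ccccc2)c1-c1ccc(Br)cc1)Nc1ccccn1` is not yet measured. It arises from compound 3 by pyridin-2-yl in place of 1,3-benzothiazol-2-yl on an amide-type nitrogen. The place line reads the same word for word as for the change from compound 1 to compound 2, so this is the same change, made on the core of compound 3 instead of the core of compound 1. Since the earlier step is unreadable, the step from compound 3 to compound 4 is expected to be small, with a step that the limit leaves unreadable from compound 3 to compound 4 as the estimate, resting on (the limit of < 50000 nM in this assay, at which 3 of the 3 values shown sit). Compound 4 is expected to fall at about 25000 nM, in the range 6000 nM to 50000 nM, and most likely to return a limit as well.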

Compound 4, half-maximal inhibitory concentration: < 50000 nM
Compound 4: only a limit was reported (the forecaster's own chance of this, stated with the estimate: 85%); the middle value is on the limit's open side.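

In this assay compound 4 gives < 50000 nM, a limit and not a number. No step can be read from compound 3 or compound 2 to compound 4, and the only evidence is the shared limit: the limit of < 50000 nM in this assay, at which 4 of the 4 values shown sit.

The compounds shown leave open where any of the four truly lies, and whether either pyridin-2-yl in place of 1,3-benzothiazol-2-yl or 4-bromophenyl in place of furan-2-yl alters cytotoxicity at all.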